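The source may report more compounds than this note shows. Statements on the series, on what has been measured and on what is new or still open speak of the compounds shown alone.

Measured in a functional assay on HUVEC cells (Homo sapiens) for inhibition, with a stated time of 4 days; a higher number here means a weaker inhibitor, a lower number a stronger inhibitor:
- compound 1 `COc1ccc(C(N)=O)cc1/C=C/c1ccccc1`: 2400 nM
- compound 2 `COc1ccc(/C=C/c2cc(C(N)=O)ccc2OC)cc1`: 8800 nM

Of these two numbers, compound 1 holds the lower, at 2400 nM, which makes it the stronger inhibitor of the pair. Within the data shown here, the only measured step is a 3.7-fold higher number from compound 1 to compound 2 (0.56 log units; beyond the scatter), and it is a modest one. It puts methoxy in place of hydrogen on an aromatic carbon.

The next compound is compound 3 `COc1ccc(C(N)=O)cc1/C=C/c1cccc(C)c1`, and it differs from compound 1 as follows: methyl in place of hydrogen on an aromatic carbon. This is methyl in place of hydrogen on an aromatic carbon, meta to a large group. Among the measured compounds shown here, no measured step covers this exact change. The closest guide is compound 2, reached by a 3.7-fold higher number from compound 1 to compound 2 (0.56 log units; beyond the scatter), since that step also replaces hydrogen on an aromatic carbon, though with a different group. On that single precedent, a small move towards a higher number is expected in this assay, smaller than the methoxy step and perhaps not beyond the scatter. The expected step is a 1.4-fold higher number from compound 1 to compound 3 (0.15 log units; within the scatter). For compound 3 the estimated value is 3400 nM, with an expected range from 1200 nM to 9500 nM.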

Compound 3, half-maximal inhibitory concentration: 3900 nM
Compound 3: middle estimate off by 1.1-fold (0.06 log units), on the low side; the range from low to high includes it.
By their numbers in this assay, from the lowest: compounds 1 and 3 (each within the scatter of the next); then compound 2.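

The methyl step reads a 1.6-fold higher number from compound 1 to compound 3 (0.21 log units; within the scatter), so in this assay methyl in place of hydrogen on an aromatic carbon, meta to a large group, gives a shift that cannot be told apart from repeat measurements. Until now the only replacement of an aromatic hydrogen on record was the methoxy change, a 3.7-fold higher number from compound 1 to compound 2 (0.56 log units; beyond the scatter), and this new result shows that such a replacement on the core of compound 1 need not move the number beyond the scatter. No measurement bearing on the reason for this result is available.

The compounds shown leave open whether this place, meta to a large group, accepts other groups in the same way, such as a chlorine atom, a hydroxyl, an amine or a longer chain such as ethyl. Among these compounds, they also leave open whether methoxy at this same place would match methyl or would give a step as large as the one seen with compound 2, and so whether the group or its place counts for more in the two steps from compound 1.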